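Amide variation across the shared core

The source may report more compounds than this note shows. Statements on the series, on what has been measured and on what is new or still open speak of the compounds shown alone.

Of the compounds shown here, three with a common core have been measured in a functional assay on MIA PaCa-2 cells (Homo sapiens) for inhibition, read by MTT assay, with a stated time of 3 days; a lower number here means a stronger inhibitor, a higher number a weaker inhibitor. Compound 1 `CCN(CC)S(=O)(=O)c1ccc(S(=O)(=O)N2CCC[C@@H](C(=O)N[C@@H]3CCN(C(=O)OC(C)(C)C)C3)C2)cc1` is one of them; in this assay compound 1 gives > 10000 nM, which is a limit of the assay and not a number. Compound 2 `CCN(CC)S(=O)(=O)c1ccc(S(=O)(=O)N2CCC[C@@H](C(=O)N(C)C(C)C)C2)cc1` also reaches only a limit, and in this assay compound 2 gives > 10000 nM. Compound 3 `CCN(CC)S(=O)(=O)c1ccc(S(=O)(=O)N2CCC[C@@H](C(=O)NC3COC3)C2)cc1` stands at the same kind of limit: in this assay compound 3 gives > 10000 nM. The step that the two limits leave unreadable from compound 1 to compound 3 and the step that the two limits leave unreadable from compound 2 to compound 3 cannot be read in size or direction because the limit of > 10000 nM in this assay, at which 3 of the 3 values shown sit, covers all three values.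

Compound 4 `CCN(CC)S(=O)(=O)c1ccc(S(=O)(=O)N2CCC[C@@H](C(=O)N3CCN(c4nc(C)no4)CC3)C2)cc1` has not been measured. Compared with compound 3 the change is 4-(3-methyl-1,2,4-oxadiazol-5-yl)piperazin-1-yl in place of (oxetan-3-yl)amino on a carbonyl carbon. Within the data shown here, the two measured steps bear on this position of the core but are unreadable, so no step of a known size or direction can be derived from them. The expected step is a number no higher from compound 3 to compound 4 (the limit leaves the size open), and a limit rather than a number is the most likely outcome. Compound 4 is estimated at 10000 nM, with a range from 3000 nM to 30000 nM.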

Compound 4, half-maximal inhibitory concentration: > 10000 nM
Compound 4: a limit, no number (the forecaster's own chance of this, stated with the estimate: 80%); the middle value sits exactly at the limit.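

In this assay compound 4 gives > 10000 nM which is a limit of the assay and not a number. The steps to compound 4 from compound 2 and compound 3 cannot be read, because all the values share one limit: the limit of > 10000 nM in this assay, at which 4 of the 4 values shown sit. The compounds shown leave open whether this assay gives a measurable value for any amide on the shared core.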